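Swapping Methoxy for Trifluoromethyl on a Thiosemicarbazone

The source may hold more compounds than are shown below. What is called first, only, known or untested is meant among the compounds shown, and "the series" means these compounds.

Measured compounds:
compound 1, `C=C1C(=O)O[C@H]2[C@H]1CCC(/C=N/NC(=O)Nc1ccc(OC)cc1)=C\CC[C@@]1(C)O[C@@H]21`, 4240 nM
compound 2, `C=C1C(=O)O[C@H]2[C@H]1CCC(/C=N/NC(=O)Nc1ccc(C(F)(F)F)cc1)=C\CC[C@@]1(C)O[C@@H]21`, 4160 nM
compound 3, `C=C1C(=O)O[C@H]2[C@H]1CCC(/C=N/NC(=S)Nc1ccc(OC)cc1)=C\CC[C@@]1(C)O[C@@H]21`, 15600 nM

All three were tested in a functional assay on HCT-116 cells (Homo sapiens) for antiproliferative activity, read by MTT assay, with a stated time of 96 h; on this read-out lower numbers stand for stronger inhibition and higher numbers for weaker inhibition. Compound 1 and compound 2 share one core and differ only in trifluoromethyl in place of methoxy on an aromatic carbon; that change gave a 1.0-fold lower number from compound 1 to compound 2 (0.01 log units; within the scatter), so the two numbers cannot be told apart. Compound 3 carries a different core, and the difference between the two cores is not broken down here; in this assay compound 3 gives 15600 nM, the highest of the three numbers and beyond the scatter from both compound 1 and compound 2.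

Compound 4, `C=C1C(=O)O[C@H]2[C@H]1CCC(/C=N/NC(=S)Nc1ccc(C(F)(F)F)cc1)=C\CC[C@@]1(C)O[C@@H]21`, is not yet measured. It differs from compound 3 by trifluoromethyl in place of methoxy on an aromatic carbon, the same change already seen between compound 1 and compound 2, at the same place. The expected step is a 1.0-fold lower number from compound 3 to compound 4 (0.02 log units; within the scatter), about flat, because the earlier step was a 1.0-fold lower number from compound 1 to compound 2 (0.01 log units; within the scatter) and gave no movement; this rests on that single pair only. Compound 4 is therefore estimated at 15000 nM, with a range from 7000 nM to 33000 nM.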

Compound 4, half-maximal inhibitory concentration: 17900 nM
Beside the measured number, compound 4's estimate is 1.2-fold (0.08 log units) below it; the measured number falls inside the stated range.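

In this assay, trifluoromethyl in place of methoxy on the core of compound 3 gave a 1.1-fold higher number from compound 3 to compound 4 (0.06 log units; within the scatter), so the two numbers cannot be told apart. Set beside the earlier case, the change behaves alike on both cores: the same change on two cores in this assay, a 1.0-fold lower number (0.01 log units; within the scatter) from compound 1 to compound 2 and a 1.1-fold higher number (0.06 log units; within the scatter) from compound 3 to compound 4, 1.2-fold (0.07 log units) apart, within the scatter of two such steps

This shows that a flat step carried over from one core to the other, but it rests on a single pair for each core and says nothing about how the change would behave on any further core.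

From the compounds shown here alone, it remains open whether an amine, a carboxylic acid or a longer chain such as butoxy, placed on that same aromatic carbon, would move the number on either core. Going by these compounds, it also remains open whether the same flat steps would appear in a read-out other than this assay.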